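Replacing the amine nitrogen group of compound 2

This account rests on a few compounds, and the source may have more. Where it says the series, first, only, none or still open, it means among the compounds named here.

Measured in a functional assay on HeLa cells (Homo sapiens) for inhibition, read by MTT assay, with a stated time of 48 h; a higher number here means a weaker inhibitor, a lower number a stronger inhibitor:
- compound 1 `CCOC(=O)C1=C(N/C=N/c2nnc(S(N)(=O)=O)s2)Nc2[nH]nc(C)c2C1c1ccc(N(C)C)cc1`: 26300 nM
- compound 2 `CCOC(=O)C1=C(N/N=C(/Cl)c2ccc([N+](=O)[O-])cc2)Nc2[nH]nc(C)c2C1c1ccc(N(C)C)cc1`: 46200 nM

Within the data shown here, compound 2 stands level with compound 1, the only other measured compound, and the two values cannot be ranked: a 1.8-fold higher number from compound 1 to compound 2 (0.24 log units; within the scatter). The next compound is compound 3 `CCOC(=O)C(=NNC1=C(C(=O)OCC)C(c2ccc(N(C)C)cc2)c2c(C)n[nH]c2N1)C(=O)OCC`. Its difference from compound 2 is a group of 12 heavy atoms (7 carbon, 1 nitrogen, 4 oxygen; no ring) in place of a group of 12 heavy atoms (7 carbon, 2 nitrogen, 2 oxygen, 1 chlorine; one six-membered aromatic ring of carbon only), on an amine nitrogen. The entering group has no ring, whereas the leaving group has one six-membered aromatic ring of carbon only.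

Among the measured compounds shown here, one measured step bears on this change, as it also exchanges the group on an amine nitrogen. For the measured compounds named here, both groups in that step carry an aromatic ring, and no measured compound has a group without a ring at this place. The data therefore do not show what loss of the ring does. Going by the values given here, with a 1.8-fold higher number from compound 1 to compound 2 (0.24 log units; within the scatter) as the only guide, no step beyond the scatter is expected in this assay, and no direction is favoured. The expected step is a 1.2-fold lower number from compound 2 to compound 3 (0.06 log units; within the scatter). Compound 3 is estimated at 40000 nM, with an expected range of 17000 nM to 90000 nM.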

Compound 3, half-maximal inhibitory concentration: 83800 nM
Beside the measured number, compound 3's estimate is 2.1-fold (0.32 log units) below it, within the range that was stated.
By their numbers in this assay, from the lowest: compounds 1, 2 and 3 (each within the scatter of the next, the first and the last beyond it).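

In this assay, a group with no ring can take the place of the group with a six-membered aromatic ring of carbon only on the amine nitrogen without a step that can be read (a 1.8-fold higher number from compound 2 to compound 3 (0.26 log units; within the scatter)). Among these compounds, the same ringless group in place of the group with a five-membered aromatic ring with 3 hetero atoms gives the first step beyond the scatter at this position, though only a modest one (a 3.2-fold higher number from compound 1 to compound 3 (0.50 log units; beyond the scatter)), so the choice of group on this nitrogen can shift the number, while compound 2 cannot be separated from either of the other two. No supporting data bear on what lies behind either step.

Going by these compounds, it remains open whether a much smaller ringless group, such as a methyl group, or a group ending in a carboxylic acid or an amine, would stay in this range when placed on the amine nitrogen. On these data alone, it is also open whether any group at this position can give a clearly lower number than compound 1 does (26300 nM), and whether the steps seen here hold outside this one assay and the shared core.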